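The compounds below may be only part of what the source reports. "The series", "measured", "known", "first", "only" and "open" are said of these compounds alone.

Measured in a functional assay on MCF7 cells (Homo sapiens) for cytotoxicity, read by MTT assay, with a stated time of 48 h; a higher number here means a weaker inhibitor, a lower number a stronger inhibitor:
compound 1 `CCC(CC)(c1ccc(OCC(O)C(C)(C)C)c(C)c1)c1ccc(C(=O)NCCCO)n1C`: 16400 nM
compound 2 `CCC(CC)(c1ccc(OCC(O)C(C)(C)C)c(C)c1)c1ccc(C(=O)N[C@H](CO)CCO)n1C`: 7.83 nM
compound 3 `CCn1c(C(=O)NCCO)ccc1C(CC)(CC)c1ccc(OCC(O)C(C)(C)C)c(C)c1`: 1810 nM

Compound 3, at 1810 nM, stands second highest of the three, below compound 1 and far above compound 2. Compound 4 `CCn1c(C(=O)N[C@H](CO)CCO)ccc1C(CC)(CC)c1ccc(OCC(O)C(C)(C)C)c(C)c1` differs from compound 3 by 2-hydroxyethyl in place of hydrogen on a saturated chain carbon bound to an amide-type nitrogen and a saturated chain carbon. Its amide then carries the 3-hydroxy-1-(hydroxymethyl)propyl group also found in compound 2. Going by the values given here, one measured step bears on this: a 2100-fold lower number from compound 1 to compound 2 (3.32 log units; beyond the scatter), which is large and ends in that same group, though from a different chain and with hydroxymethyl entering. A large step to a lower number is therefore expected in this assay, estimated as a 150-fold lower number from compound 3 to compound 4 (2.18 log units; beyond the scatter). For compound 4 the estimated value is 12 nM, with an expected range of 1.5 nM to 200 nM.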

Compound 4, half-maximal inhibitory concentration: 300 nM
Compound 4: middle estimate off by 25-fold (1.40 log units), on the low side, and the stated range ends below it.
By their numbers in this assay, from the lowest: compound 2; then compound 4; then compound 3; then compound 1.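

In this assay, 2-hydroxyethyl in place of hydrogen on the saturated chain carbon bound to the amide-type nitrogen gives only a 6.0-fold lower number from compound 3 to compound 4 (0.78 log units; beyond the scatter), so the same end group does not bring the same size of step in every compound. With 3-hydroxy-1-(hydroxymethyl)propyl held constant, methyl in place of hydrogen on a saturated chain carbon bound to an aromatic nitrogen gives a 38-fold higher number from compound 2 to compound 4 (1.58 log units; beyond the scatter), a large change from a small addition. No supporting evidence accounts for either step.

Open, as far as these compounds go, is whether a longer chain on that aromatic nitrogen moves the number further. Also open, from the compounds shown here alone, is whether an amine in place of either hydroxyl of the amide chain retains the low number of compound 2.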